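From a Substituted Phenyl Amine to a Pyrrolidine

The source may hold more compounds than are shown below. What is called first, only, known or untested is meant among the compounds shown, and "the series" means these compounds.

Measured in a functional assay on HeLa cells (Homo sapiens) for inhibition, read by sulforhodamine B assay; on this read-out higher numbers stand for weaker inhibition and lower numbers for stronger inhibition:
- compound 1 `O=C1C(Nc2ccc(I)cc2)=CC(=O)c2c1nc1n2[C@H]2OC[C@@H](O)[C@H]2OC1` gives 4010 nM
- compound 2 `O=C1C(Nc2ccccc2F)=CC(=O)c2c1nc1n2[C@H]2OC[C@@H](O)[C@H]2OC1` gives 9820 nM
- compound 3 `Cc1ccc(NC2=CC(=O)c3c(nc4n3[C@H]3OC[C@@H](O)[C@H]3OC4)C2=O)cc1` gives 6590 nM

All three compounds carry a substituted phenyl group on an amine nitrogen. Compound 3 cannot be separated from either of the others, since a 1.6-fold higher number from compound 1 to compound 3 (0.22 log units; within the scatter) and a 1.5-fold lower number from compound 2 to compound 3 (0.17 log units; within the scatter). The next compound, compound 4 `O=C1C(N2CCCC2)=CC(=O)c2c1nc1n2[C@H]2OC[C@@H](O)[C@H]2OC1`, has pyrrolidin-1-yl in place of (4-methylphenyl)amino on a double-bonded ring carbon.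

The largest measured step is modest, at a 2.4-fold higher number from compound 1 to compound 2 (0.39 log units; beyond the scatter). That step and the two above only exchange one phenyl-bearing group for another, so none of them tests this replacement directly. They offer no ground for predicting a shift, and no step beyond the scatter is expected in this assay, though with wide uncertainty. For compound 4 the expected change is a 1.1-fold lower number from compound 3 to compound 4 (0.04 log units; within the scatter). Compound 4 is estimated at 6000 nM, within an expected range from 2000 nM to 18000 nM.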

Compound 4, half-maximal inhibitory concentration: > 16000 nM
Compound 4 ended at the assay's limit; the forecaster's own chance of this, stated with the estimate: 10%; middle value at least 2.6-fold (0.42 log units) from the limit.
By their numbers in this assay, from the lowest: compounds 1, 3 and 2 (each within the scatter of the next, the first and the last beyond it). At a limit, above all of these: compound 4.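

Compound 4 stands at a limit of this assay, > 16000 nM, and not at a number: the limit of > 16000 nM in this assay, at which 1 of the 4 values shown sits. Pyrrolidin-1-yl on the double-bonded ring carbon removes both the phenyl ring and the amine hydrogen-bond donor, and this position proves sensitive to that change, with an at least 2.4-fold higher number from compound 3 to compound 4 (0.38 log units; beyond the scatter) and an at least 3.9-fold higher number from compound 1 to compound 4 (0.60 log units; beyond the scatter). Against the 2-fluorophenyl compound the step is an at least 1.6-fold higher number from compound 2 to compound 4 (0.21 log units; that floor lies within the scatter), so compound 2 and compound 4 are not separated.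

The compounds shown do not tell whether the loss follows the aromatic ring or the donor, since both leave together. A cyclopentylamino group, which keeps the amine hydrogen without the phenyl ring, or an N-methyl-N-phenylamino group, which keeps the phenyl ring without that hydrogen, would pull the two apart.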